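The source may hold more compounds than are shown below. What is called first, only, known or untested is meant among the compounds shown, and "the series" means these compounds.

Working notes on the series. Among the compounds with values here, in a functional assay on CCRF-CEM cells (Homo sapiens) for antiproliferative activity (a higher number here means a weaker inhibitor, a lower number a stronger inhibitor), compound 1 (`COc1cc(C(=O)c2sc(-c3ccc(C)cc3)cc2N)cc(OC)c1OC`) gives 15 nM and compound 2 (`COc1cc(C(=O)c2sc(-c3cccs3)cc2N)cc(OC)c1OC`) gives 9.4 nM, so compound 2 stands within the scatter of the only other measured value. Compound 3 (`CCOc1ccc(-c2cc(N)c(C(=O)c3cc(OC)c(OC)c(OC)c3)s2)cc1`) differs from compound 2 as follows: 4-ethoxyphenyl in place of thiophen-2-yl on an aromatic carbon. Within the data shown here, the one measured step, a 1.6-fold lower number from compound 1 to compound 2 (0.20 log units; within the scatter), exchanges groups at this same place and stays within the scatter. Among the measured compounds shown here, no measured compound carries an ethoxy group, so the range is kept wide. The expected step, a 1.3-fold higher number from compound 2 to compound 3 (0.11 log units; within the scatter), is estimated to stay within the scatter. The estimate for compound 3 is 12 nM, with an expected range of 4 nM to 40 nM.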

Compound 3, half-maximal inhibitory concentration: 270 nM
For compound 3 the middle estimate is 23-fold (1.35 log units) below the measured one, and the stated range ends below it.
By their numbers in this assay, from the lowest: compounds 2 and 1 (each within the scatter of the next); then compound 3.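

At this position a change of aryl group is not always silent: a 29-fold higher number from compound 2 to compound 3 (1.46 log units; beyond the scatter) and an 18-fold higher number from compound 1 to compound 3 (1.26 log units; beyond the scatter) are both large, unlike the earlier exchange at this place. The second step shows that ethoxy in place of methyl on an aromatic carbon is enough for a large change, with the rest of compound 1 unchanged. Nothing measured on hand bears on the reason for this result. The compounds shown leave open whether a methoxy group or a longer chain such as propoxy in place of the ethoxy group keeps the number this high, and whether an amine there would behave the same way.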